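Methyl on the tetrazole: compound 3 to compound 4

This account rests on a few compounds, and the source may have more. Where it says the series, first, only, none or still open, it means among the compounds named here.

Measured so far:
compound 1 `CCc1cc(C(C)=O)c(O)cc1OCCCCCCC(C)(C)C#N` — 30%
compound 2 `CCc1cc(C(C)=O)c(O)cc1OCCCCCC(C)(C)C(=O)O` — 73%
compound 3 `CCc1cc(C(C)=O)c(O)cc1OCCCCCCC(C)(C)c1nnn[nH]1` — 67%

In an assay on isolated protein for binding affinity to leukotriene B4 receptor 1 (Homo sapiens), tested at 1 uM (a higher number here means more inhibition at the concentration tested (going by the name of the read-out), a lower number less inhibition), compound 3 gives 67%, the second highest of the three numbers. Its nearest neighbour is compound 2, which gives 73%, the gap being a number 6 percentage points lower from compound 2 to compound 3 (within the scatter). The farthest is compound 1 with 30%; the step of a number 37 percentage points higher from compound 1 to compound 3 (beyond the scatter) is large, as is the related step of a number 43 percentage points higher from compound 1 to compound 2 (beyond the scatter).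

Compound 4 `CCc1cc(C(C)=O)c(O)cc1OCCCCCC(C)(C)c1nnnn1C` has not been tested. It differs from compound 3 by 1-methyl-1-(1-methyl-1H-tetrazol-5-yl)ethyl in place of 2-(1H-tetrazol-5-yl)-2-methylpropyl on a saturated chain carbon, five bonds along the chain from an oxygen on an aromatic ring. The change leaves the count of atoms unchanged but removes the single hydrogen-bond donor of the group. Within the data shown here, no measured step exchanges one tetrazole for another, so the nearest guide is that the only measured compound without a hydrogen-bond donor in this part of the chain, compound 1, gives 30%, while the two compounds carrying a donor, compound 2 and compound 3, sit far higher.

On that basis a downward step a number 27 percentage points lower from compound 3 to compound 4 (beyond the scatter) is expected for compound 4, though with wide uncertainty. Compound 4 is estimated at 40%, within a range from 18% to 62%.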

Compound 4, a percentage reported as inhibition, at one concentration (the size of the read-out at that concentration, not a potency): 59%
Compound 4: the middle estimate sits 19 percentage points below what was measured, and the stated range covers the measured number.
By their numbers in this assay, from the lowest: compound 1; then compounds 4, 3 and 2 (each within the scatter of the next, the first and the last beyond it).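

In this assay, among these compounds, the 1-methyl-1-(1-methyl-1H-tetrazol-5-yl)ethyl group has no hydrogen-bond donor, yet the step stays within the scatter (a number 8 percentage points lower from compound 3 to compound 4 (within the scatter)), so the low number of compound 1, the only earlier compound without a donor here, does not extend to every donor-free group at this position. The methyl-capped tetrazole keeps a clear margin over the cyano group (a number 29 percentage points higher from compound 1 to compound 4 (beyond the scatter)) but falls modestly short of the carboxy group (a number 14 percentage points lower from compound 2 to compound 4 (beyond the scatter)). Nothing available explains these steps.

The compounds shown leave open how a methyl ester or a primary amide would read at this position. They also leave open whether the isomeric 2-methyl-2H-tetrazol-5-yl group would match the 1-methyl isomer.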